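The source may report more compounds than this note shows. Statements on the series, on what has been measured and on what is new or still open speak of the compounds shown alone.

Compound 1 `COc1cc(-c2cc(/C=C/C(=O)c3ccc(Cl)c(Cl)c3)[nH]n2)cc(OC)c1OC` stands highest of the two numbers in a functional assay on SK-MEL-28 cells (Homo sapiens) for cytotoxicity, read by sulforhodamine B assay, with a stated time of 48 h, tested at 10 uM; on this read-out higher numbers stand for a weaker effect at the one concentration tested and lower numbers for a stronger effect; compound 1 gives 73% there. Compound 2 `COc1ccc(-c2cc(/C=C/C(=O)c3ccc(N)cc3)[nH]n2)cc1OC` gives -29% in this assay, a number far beyond the scatter below compound 1; the two differ in more than one place, so only the two values are known. Compound 3 `COc1ccc(C(=O)/C=C/c2cc(-c3cc(OC)c(OC)c(OC)c3)n[nH]2)cc1OC` differs from compound 1 by 3,4-dimethoxyphenyl in place of 3,4-dichlorophenyl on a carbonyl carbon. Going by the values given here, no step of this kind has been measured. Compound 3 is expected to sit somewhat lower than compound 1, by about a number 18 percentage points lower from compound 1 to compound 3 (beyond the scatter) in this assay, with wide uncertainty. The estimate for compound 3 is 55%, within 5% to 95%.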

Compound 3, a percentage reported as activity, at one concentration (the size of the read-out at that concentration, not a potency): -88%
Compound 3: middle estimate off by 143 percentage points, on the high side, outside the stated range (below it).
By their numbers in this assay, from the lowest: compound 3; then compound 2; then compound 1.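

Working from a single change for the first time, the group on the carbonyl carbon proves decisive in this assay: 3,4-dimethoxyphenyl in place of 3,4-dichlorophenyl gives a number 161 percentage points lower from compound 1 to compound 3 (beyond the scatter), towards the stronger effect. This one place is therefore enough to move the series from a weak effect to a strong one, with the rest of the core of compound 1 unchanged. No measurement here accounts for the size of this step.

From the compounds shown here alone, whether the gain follows the methoxy groups or the loss of the chlorine atoms remains open. Also open, going by these compounds, is where a plain phenyl, or ethoxy groups in place of the methoxy groups, would fall at this carbonyl carbon.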